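Removing a Ring Hydroxy from an Adenine Nucleoside Analogue

A few compounds are considered here, and "the series" means these few. Any claim that something is new, unique, unknown or untested is made for them only; others in the source may bear on it.

compound 1 `OC[C@@]1(O)CO[C@@H](n2cnc3c(NCc4cccc(Cl)c4)ncnc32)[C@@H]1O` – 10%
compound 2 `Nc1ncnc2c1ncn2[C@@H]1OC[C@H](CO)[C@H]1O` – 6%
compound 3 `OC[C@]1(O)CO[C@@H](n2cnc3c(NCc4cccc(Cl)c4)ncnc32)[C@@H]1O` – 19%

Of the compounds shown here, three have been measured in an assay on CHO cells for displacement of a labelled ligand from adenosine receptor A1 (Homo sapiens), tested at 10 uM; on this read-out lower numbers stand for less inhibition and higher numbers for more inhibition at the one concentration tested (going by the name of the read-out). Compound 1 gives 10%, compound 2 gives 6%, and compound 3 gives 19%. Compound 2 has the lowest of the three numbers, but its gap to compound 1 is within the usual scatter of repeated measurements, so the two cannot be told apart; only its gap to compound 3 is beyond that scatter.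

For the measured compounds named here, the only step between two compounds that differ in one place is a number 9 percentage points higher from compound 1 to compound 3 (within the scatter), and it rests on (the fact that compounds 1 and 3 differ only in the configuration as drawn). That step concerns a change of configuration at a ring carbon, not the loss of a group, so it offers no direct guide to the change now in question.

Compound 4 `Nc1ncnc2c1ncn2[C@H]1C[C@@H](CO)CO1` differs from compound 2 as follows: hydrogen in place of hydroxy on a saturated ring carbon. Going by the values given here, no measured step bears on this kind of change, so the expectation for compound 4 in this assay rests on the low numbers of all three measured compounds. Compound 4 is therefore expected to give about 7%, in a range from 0% to 22%. The expected step is a number 1 percentage points higher from compound 2 to compound 4 (within the scatter), which is none beyond the scatter.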

Compound 4, a percentage reported as inhibition, at one concentration (the size of the read-out at that concentration, not a potency): 10%
Estimate against measurement, compound 4: 3 percentage points below, and the stated range covers the measured number.
By their numbers in this assay, from the lowest: compounds 2, 1, 4 and 3 (each within the scatter of the next, the first and the last beyond it).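

For the compounds shown here, the new pair gives the first direct reading of this change: with hydrogen in place of hydroxy on a saturated ring carbon, two ring bonds from the ring oxygen and next to the ring atom that bears a hydroxymethyl group, the result in this assay is a number 4 percentage points higher from compound 2 to compound 4 (within the scatter) and so compound 2 and compound 4 cannot be told apart. At this position, then, the hydroxy can be replaced without a difference this measurement can detect, although both numbers are low at the one concentration tested and leave little room for a loss to show. Nothing available explains this result, since the only background on hand concerns a difference in configuration between two other compounds.

Going by these compounds, whether a different group on this carbon, such as an amine, a methoxy group or a fluorine atom, would give a number beyond the scatter from compound 2 remains open. Also open, on these data alone, is whether compound 2 and compound 4 would still be indistinguishable at other concentrations, which would show whether either has a stronger or weaker effect there than at the one concentration tested.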